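Methoxy to methylamino on a cytidine diphosphate core

This account rests on a few compounds, and the source may have more. Where it says the series, first, only, none or still open, it means among the compounds named here.

Measured compounds:
compound 1, `Nc1nc(=O)ccn1[C@@H]1O[C@H](COP(=O)(O)O)[C@@H](O)[C@H]1O`, > 100000 nM
compound 2, `COc1nc(=O)ccn1[C@@H]1O[C@H](COP(=O)(O)O)[C@@H](O)[C@H]1O`, 9800 nM
compound 3, `COc1nc(=O)ccn1[C@@H]1O[C@H](COP(=O)(O)OP(=O)(O)O)[C@@H](O)[C@H]1O`, 1370 nM

The measurements come from an in vitro functional assay on 1321-N1 cells for agonist activity at P2Y purinoceptor 6 (Homo sapiens), read by scintillation proximity assay and inositol phosphate accumulation; on this read-out lower numbers stand for an effect already at smaller amounts and higher numbers for an effect only at larger amounts of compound. Compound 1 gives only a limit of the assay, > 100000 nM, which is the limit of > 100000 nM in this assay, at which 1 of the 3 values shown sits. Compound 2 gives 9800 nM, and compound 3 gives 1370 nM, the lowest of the two real numbers shown.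

Two measured steps surround compound 3. The first is an at least 10-fold lower number from compound 1 to compound 2 (1.00 log units; beyond the scatter). The second is a 7.2-fold lower number from compound 2 to compound 3 (0.85 log units; beyond the scatter).

Compound 4, `CNc1nc(=O)ccn1[C@@H]1O[C@H](COP(=O)(O)OP(=O)(O)O)[C@@H](O)[C@H]1O`, has not yet been measured. It differs from compound 3 in one place: methylamino in place of methoxy on an aromatic carbon. The step from compound 1 to compound 2 bears on this change, since it too alters the group on that aromatic carbon; it showed that amino is far worse than methoxy there. Methylamino is neither of these, so for compound 4 the account expects a step of a 2.6-fold higher number from compound 3 to compound 4 (0.41 log units; beyond the scatter), toward a higher number. Compound 4 is therefore estimated at 3500 nM, with a range from 900 nM to 14000 nM.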

Compound 4, half-maximal effective concentration: > 100000 nM
Compound 4 gave a limit, no number (the forecaster's own chance of this, stated with the estimate: 10%); at least 28-fold (1.45 log units) between middle value and limit.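

In this assay compound 4 gives only a limit and not a number, the same limit at which compound 1 sits: the limit of > 100000 nM in this assay, at which 2 of the 4 values shown sit. Methylamino in place of methoxy on this aromatic carbon, between two ring nitrogen atoms, gives an at least 72-fold higher number from compound 3 to compound 4 (1.86 log units; beyond the scatter), a large step. The earlier pair had set only amino against methoxy, on the monophosphate; this pair shows that methylamino also falls far short of methoxy at this place, and that the same preference holds on the diphosphate.

On these data alone, how large the step really is stays unknown, since compound 4 has no number. As far as these compounds go, whether ethoxy, methylthio or dimethylamino on this carbon would keep the effect seen with methoxy remains open, as does whether the loss comes from the nitrogen itself or from its hydrogen.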